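From Dimethylamino to Phenyl on a Shared Core

This account rests on a few compounds, and the source may have more. Where it says the series, first, only, none or still open, it means among the compounds named here.

Compound 1 `COc1ccc(C(=O)/C=C/c2ccc(F)cc2)c2c1C=CC(C)(C)O2`: in a functional assay on HepG2 cells (Homo sapiens) for antiproliferative activity, read by MTT assay, with a stated time of 24 h (on this read-out higher numbers stand for weaker inhibition and lower numbers for stronger inhibition), compound 1 gives > 10000 nM, which is a limit of the assay and not a number.
Compound 2 `COc1ccc(C(=O)/C=C/c2ccc(Br)cc2)c2c1C=CC(C)(C)O2`: in this assay compound 2 gives > 10000 nM, again a limit and not a number.
Compound 3 `COc1ccc(C(=O)/C=C/c2ccc(N(C)C)cc2)c2c1C=CC(C)(C)O2`: in this assay compound 3 gives 730 nM.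

Compound 3 therefore stands alone: its value is the only number shown, while the two other values sit at the limit of > 10000 nM in this assay, at which 2 of the 3 values shown sit. The step from compound 1 to compound 2 is left unreadable by the two limits (a step that the two limits leave unreadable from compound 1 to compound 2). The two steps that reach compound 3 are large: an at least 13-fold lower number from compound 1 to compound 3 (1.13 log units; beyond the scatter) and an at least 13-fold lower number from compound 2 to compound 3 (1.13 log units; beyond the scatter).

Compound 4 `COc1ccc(C(=O)/C=C/c2ccc(-c3ccccc3)cc2)c2c1C=CC(C)(C)O2` has not yet been measured in this assay. It differs from compound 3 in one place: phenyl in place of dimethylamino on an aromatic carbon. Both measured steps that bear on this position point the same way: the dimethylamino group, which compound 4 loses, is the only substituent that gave a readable number, whereas fluoro and bromo each gave a limit. The expectation for compound 4 is accordingly a move toward weaker inhibition, a step of roughly a 6.8-fold higher number from compound 3 to compound 4 (0.84 log units; beyond the scatter), with a real chance that only a limit is reported. The estimated value for compound 4 is 5000 nM, within a range from 1500 nM to 15000 nM.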

Compound 4, half-maximal inhibitory concentration: > 10000 nM
Compound 4 ended at the assay's limit; the forecaster's own chance of this, stated with the estimate: 35%; middle value at least 2.0-fold (0.30 log units) from the limit.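

In this assay, phenyl in place of dimethylamino on an aromatic carbon gives an at least 13-fold higher number from compound 3 to compound 4 (1.13 log units; beyond the scatter), so a group with a six-membered aromatic ring of carbon only does not keep the readable value of compound 3. The earlier compounds shown here set dimethylamino against fluoro and bromo alone, whereas compound 4 shows that a substituent at this position need not be a halogen to end at a limit, leaving compound 3 as the only one of the four with a number: the limit of > 10000 nM in this assay, at which 3 of the 4 values shown sit. The steps that join compound 1, compound 2 and compound 4 cannot be read, with a limit at both ends of each, so these three cannot be placed in any order.

The compounds shown leave open whether the readable value belongs to dimethylamino alone or would also appear with another nitrogen group at this position, such as a primary amine, pyrrolidine or morpholine, or with an oxygen group such as methoxy. They also leave open how far beyond the limit fluoro, bromo and phenyl lie on the shared core.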